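Chain substituent on the ring nitrogen in a nucleoside series

A few compounds are considered here, and "the series" means these few. Any claim that something is new, unique, unknown or untested is made for them only; others in the source may bear on it.

Measured so far in a functional assay (B cells) with Mus musculus as the target; on this read-out higher numbers stand for an effect only at larger amounts of compound and lower numbers for an effect already at smaller amounts:
compound 1 `CCn1c(=O)n(C2OC(CO)[C@@H](O)[C@H]2O)c2nc(N)nc(O)c21`: 15 uM
compound 2 `NC(=O)Cn1c(=O)n(C2OC(CO)[C@@H](O)[C@H]2O)c2nc(N)nc(O)c21`: 190 uM
compound 3 `CCOC(=O)Cn1c(=O)n(C2OC(CO)[C@@H](O)[C@H]2O)c2nc(N)nc(O)c21`: 48 uM

Compound 3 holds the second highest of the three numbers. Its nearest neighbour is compound 1, as the step of a 3.2-fold higher number from compound 1 to compound 3 (0.51 log units; beyond the scatter) shows; its furthest is compound 2, as the step of a 4.0-fold lower number from compound 2 to compound 3 (0.60 log units; beyond the scatter) shows. Both gaps lie beyond the scatter.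

Compound 4 `Nc1nc(O)c2c(n1)n(C1OC(CO)[C@@H](O)[C@H]1O)c(=O)n2Cc1ccccc1` differs from compound 3 by phenyl in place of ethoxycarbonyl on a saturated chain carbon bound to an aromatic nitrogen. Within the data shown here, no measured step exchanges an ethoxycarbonyl for a phenyl. Among the measured compounds shown here, the steps that bear on it are a 3.2-fold higher number from compound 1 to compound 3 (0.51 log units; beyond the scatter) and a 13-fold higher number from compound 1 to compound 2 (1.10 log units; beyond the scatter), where a methyl on this chain carbon was replaced by groups carrying carbonyl and acceptor atoms and the number rose each time, and a 4.0-fold lower number from compound 2 to compound 3 (0.60 log units; beyond the scatter), where ethoxy for amino on the carbonyl lowered it. The entering phenyl carries no hydrogen-bond acceptor, and the leaving ethoxycarbonyl carries two, so the expectation is a modest lowering, toward the number of compound 1, without a firm basis for going further.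

Compound 4 is expected to give about 20 uM in this assay, within 6 uM to 70 uM, which means an expected step of a 2.4-fold lower number from compound 3 to compound 4 (0.38 log units; beyond the scatter).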

Compound 4, concentration for half-maximal effect: 6 uM
Compound 4: the middle estimate sits 3.3-fold (0.52 log units) above what was measured, and the stated range covers the measured number.
By their numbers in this assay, from the lowest: compound 4; then compound 1; then compound 3; then compound 2.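

In this assay, among these compounds, the earlier compounds showed the number only rising when methyl on this saturated chain carbon bound to an aromatic nitrogen was replaced, but phenyl in place of methyl gives a 2.5-fold lower number from compound 1 to compound 4 (0.40 log units; beyond the scatter), so replacing methyl here need not raise it. Phenyl in place of ethoxycarbonyl gives an 8.0-fold lower number from compound 3 to compound 4 (0.90 log units; beyond the scatter), and phenyl in place of carbamoyl gives a 32-fold lower number from compound 2 to compound 4 (1.50 log units; beyond the scatter), which places compound 4 lowest of the four and extends the order at this position to phenyl, methyl, ethoxycarbonyl, carbamoyl, from the lowest number to the highest. Nothing in hand explains this order.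

The four compounds do not separate the effect of the aromatic ring from that of the carbon-only makeup of the entering group: cyclohexyl or a longer chain such as butyl would test this at the same place. From the compounds shown here alone, it also remains open how the number responds to a ring carrying a heteroatom, such as pyridyl, to a substituted phenyl such as 4-chlorophenyl, or to a carboxylic acid or an amine on the chain.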